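Swapping the methyl of compound 3 for hydrogen

This account rests on a few compounds, and the source may have more. Where it says the series, first, only, none or still open, it means among the compounds named here.

- compound 1 `COc1ccc(Nc2nnc(Cl)c(Nc3cc(OC)c(OC)c(OC)c3)n2)cc1`: 13500 nM
- compound 2 `COc1cccc(Nc2nnc(Cl)c(Nc3cc(OC)c(OC)c(OC)c3)n2)c1`: 11300 nM
- compound 3 `COc1cc(Nc2nc(Nc3ccc(C)cc3)nnc2Cl)cc(OC)c1OC`: 14300 nM

In a functional assay on PC-3 cells (Homo sapiens) for inhibition, read by MTT assay, with a stated time of 48 h (a higher number here means a weaker inhibitor, a lower number a stronger inhibitor), compound 3 gives 14300 nM, and the data cannot tell it apart from the other two compounds. Compound 4 `COc1cc(Nc2nc(Nc3ccccc3)nnc2Cl)cc(OC)c1OC` differs from it as follows: hydrogen in place of methyl on an aromatic carbon. In words, this is hydrogen in place of methyl on an aromatic carbon. For the measured compounds named here, three measured steps bear on this change: a 1.1-fold higher number from compound 1 to compound 3 (0.03 log units; within the scatter), a 1.2-fold lower number from compound 1 to compound 2 (0.08 log units; within the scatter) and a 1.3-fold higher number from compound 2 to compound 3 (0.10 log units; within the scatter). All three stay within the scatter, although none of them removes a group outright. No step beyond the scatter is therefore expected in this assay. The expected step is a 1.1-fold lower number from compound 3 to compound 4 (0.04 log units; within the scatter). For compound 4 the estimate is 13000 nM, with an expected range of 7000 nM to 24000 nM.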

Compound 4, half-maximal inhibitory concentration: 9750 nM
The estimate for compound 4 lay 1.3-fold (0.12 log units) above the measured number, and the stated range covers the measured number.
By their numbers in this assay, from the lowest: compounds 4, 2, 1 and 3 (each within the scatter of the next).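

Taking the group off this ring altogether, which the earlier compounds did not do, still gives no step beyond the scatter in this assay at all: a 1.5-fold lower number from compound 3 to compound 4 (0.17 log units; within the scatter) for the methyl, and a 1.4-fold lower number from compound 1 to compound 4 (0.14 log units; within the scatter) and a 1.2-fold lower number from compound 2 to compound 4 (0.06 log units; within the scatter) for the two methoxy groups. Among these four compounds, then, a group on this ring is not needed for numbers of this size. Nothing measured here offers a reason for this. From the compounds shown here alone, whether an amine, a carboxylic acid or a longer chain on this ring would give a step beyond the scatter stays open.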